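Trifluoromethoxy in place of methyl on an aromatic carbon

A few compounds are considered here, and "the series" means these few. Any claim that something is new, unique, unknown or untested is made for them only; others in the source may bear on it.

In a functional assay on HeLa cells (Homo sapiens) for antiproliferative activity, read by MTT assay, with a stated time of 72 h (a higher number here means a weaker inhibitor, a lower number a stronger inhibitor), compound 1 (`CCCNC(=O)c1cc(Oc2ccc(NC(=O)c3nn(-c4ccc(C)cc4)c(=O)cc3C)cc2F)ccn1`) gives 14200 nM and compound 2 (`CCCNC(=O)c1cc(Oc2ccc(NC(=O)c3nn(-c4ccccc4C)c(=O)cc3C)cc2F)ccn1`) gives 24600 nM. Among the measured compounds shown here, these two values lie within the scatter of each other, so compound 2 cannot be separated from compound 1 on the numbers so far.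

Compound 3 (`CCCNC(=O)c1cc(Oc2ccc(NC(=O)c3nn(-c4ccccc4OC(F)(F)F)c(=O)cc3C)cc2F)ccn1`) carries trifluoromethoxy in place of methyl on an aromatic carbon of compound 2, ortho to a large group: trifluoromethoxy in place of methyl on an aromatic carbon.

For the measured compounds named here, the only measured step is a 1.7-fold higher number from compound 1 to compound 2 (0.24 log units; within the scatter), with 2-methylphenyl in place of 4-methylphenyl on an aromatic nitrogen. It lies within the scatter and does not involve trifluoromethoxy, so it offers only weak guidance. On that basis, no step beyond the scatter is expected in this assay, and no direction can be set.

The estimated step is a 1.1-fold lower number from compound 2 to compound 3 (0.05 log units; within the scatter). For compound 3 the expected value is 22000 nM, with an estimated range of 9000 nM to 55000 nM.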

Compound 3, half-maximal inhibitory concentration: 3690 nM
Compound 3: middle estimate off by 6.0-fold (0.78 log units), on the high side; measured number outside the range, below it.
By their numbers in this assay, from the lowest: compound 3; then compounds 1 and 2 (each within the scatter of the next).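

In this assay, among the compounds shown here, this position on the six-membered aromatic ring proves responsive: moving methyl had stayed within the scatter, at a 1.7-fold higher number from compound 1 to compound 2 (0.24 log units; within the scatter), but trifluoromethoxy in place of methyl gives a 6.7-fold lower number from compound 2 to compound 3 (0.82 log units; beyond the scatter), the first change here to separate two compounds. The 2-(trifluoromethoxy)phenyl group also stands apart from 4-methylphenyl, with a 3.8-fold lower number from compound 1 to compound 3 (0.59 log units; beyond the scatter), so compound 3 has the lowest number of the three, with its steps to both others beyond the scatter. Nothing available explains this gain.

Still open, on these data alone, is whether methoxy, trifluoromethyl or chlorine at the same place would give a comparable step, or whether the step is specific to trifluoromethoxy. Also open, as far as these compounds go, is whether the step would hold with a longer chain or an amine in place of the propyl amide end of the shared core.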